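A few compounds are considered here, and "the series" means these few. Any claim that something is new, unique, unknown or untested is made for them only; others in the source may bear on it.

In an ADME assay on PA-1 cells (Homo sapiens) for cytotoxicity, read by MTT assay, with a stated time of 72 h (on this read-out higher numbers stand for weaker inhibition and lower numbers for stronger inhibition), the measured compounds stand as follows.

Compound 1 `C=CCOc1cc(C2=C(c3cc(OC)c(OC)c(OC)c3)C(=O)C(O)C2)ccc1OC` - > 100 ug/mL (a limit)
Compound 2 `COc1cc(C2=C(c3cc(C)c(OC)c(C)c3)C(OC(C)=O)CC2=O)cc(OC)c1OC` - > 100 ug/mL (a limit)
Compound 3 `COc1ccc(C2=C(c3cc(OC)c(OC)c(OC)c3)C(=O)C(OC(C)=O)C2)cc1F` - > 100 ug/mL (a limit)

Compound 1 has no numerical value in this assay. It is recorded only as > 100 ug/mL, which is a limit. Within the data shown here, the other two compounds are recorded in the same way, so the series so far is summed up by the limit of > 100 ug/mL in this assay, at which 3 of the 3 values shown sit. Among the measured compounds shown here, no compound can therefore be ranked against another, and no step between measured compounds is available to serve as a guide.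

Compound 4 `COc1ccc(C2=C(c3cc(OC)c(OC)c(OC)c3)C(=O)C(O)C2)cc1Cl` keeps the core of compound 1 and changes one substituent, with chloro in place of allyloxy on an aromatic carbon. The new chloro group sits ortho to a methoxy group and meta to a large group.

For the measured compounds named here, with no measured step to draw on, the expectation rests on compound 1 and on (the limit of > 100 ug/mL in this assay, at which 3 of the 3 values shown sit). No shift beyond the usual scatter is expected in this assay, although a limit leaves open a move toward stronger inhibition. The expected change is a number no higher from compound 1 to compound 4 (the limit leaves the size open). For compound 4 the estimated value is 100 ug/mL, with an expected range from 10 ug/mL to 200 ug/mL.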

Compound 4, half-maximal inhibitory concentration: > 100 ug/mL
Compound 4 gave a limit, no number (the forecaster's own chance of this, stated with the estimate: 65%); the middle value lies on the limit itself.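

Among these compounds, compound 1 and compound 4 are both recorded only as limits in this assay, so no step between them can be read. The compounds shown leave open whether chloro in place of allyloxy on an aromatic carbon shifts the read-out at all, and how the compounds rank against one another, with the series summed up so far by one line: the limit of > 100 ug/mL in this assay, at which 4 of the 4 values shown sit.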